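This account rests on a few compounds, and the source may have more. Where it says the series, first, only, none or still open, it means among the compounds named here.

Measured compounds in an assay on isolated protein (Mus musculus) for inhibition of IL15-IL15 receptor (Homo sapiens), read by resazurin assay, with stated times of 30 min and 2.5 days; a higher number here means a weaker inhibitor, a lower number a stronger inhibitor:

- compound 1 `Cn1c(Cc2nn(C)c(=O)c3ccccc23)nnc1SCCCCCCCC(=O)Nc1ccc(I)cc1`: 1300 nM
- compound 2 `Cn1c(Cc2nn(C)c(=O)c3ccccc23)nnc1SCC(=O)Nc1ccc(F)cc1F`: "not active" (no number reported) (no number was reported)
- compound 3 `Cn1c(Cc2nn(C)c(=O)c3ccccc23)nnc1SCCCCCCCC(=O)Nc1ccc(Br)cc1Br`: 1500 nM

Among the compounds with values here, compound 3 and compound 1 lie within the usual scatter of each other, as the single measured step of a 1.2-fold higher number from compound 1 to compound 3 (0.06 log units; within the scatter) shows; compound 2 differs from both in more than one place and gives no number, so it offers no step. Compound 3 therefore stands alongside compound 1 with nothing between them that counts as a difference.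

Compound 4 `COc1ccc(NC(=O)CCCCCCCSc2nnc(Cc3nn(C)c(=O)c4ccccc34)n2C)cc1` is the next entry, not yet measured. The change from compound 3 is 4-methoxyphenyl in place of 2,4-dibromophenyl on an amide-type nitrogen. Within the data shown here, the only measured step, from compound 1 to compound 3, exchanged one halogenated phenyl for another and stayed within the scatter; no measured step exchanges a halogenated phenyl for a methoxyphenyl, so nothing bears directly on this change. With no step beyond the scatter anywhere in the series, the expectation for compound 4 is a step of no change at the digits printed from compound 3 to compound 4 (within the scatter), within the scatter. Compound 4 is estimated at 1500 nM in this assay, with a range from 600 nM to 4000 nM.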

Compound 4, half-maximal inhibitory concentration: 3900 nM
Compound 4: middle estimate off by 2.6-fold (0.41 log units), on the low side; low and high end bracket the measured number.
By their numbers in this assay, from the lowest: compounds 1 and 3 (each within the scatter of the next); then compound 4.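

In this assay, the aryl group on the amide-type nitrogen now shows its first change beyond the scatter: replacing 2,4-dibromophenyl with 4-methoxyphenyl gives a 2.6-fold higher number from compound 3 to compound 4 (0.41 log units; beyond the scatter), and replacing iodo with methoxy on an aromatic carbon gives a 3.0-fold higher number from compound 1 to compound 4 (0.48 log units; beyond the scatter). The two halogenated compounds, which could not be told apart, both have lower numbers than the methoxy compound, although both steps are modest and both rest on this one methoxy compound. Nothing at hand explains the shift.

As far as these compounds go, whether a dimethylamino group or a carboxylic acid on the phenyl ring would fall with the halogenated compounds or with compound 4 remains open. From the compounds shown here alone, it is also open whether a longer chain would change the number while the 4-methoxyphenyl group stays in place.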